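Methoxy to hydroxy on the aryl ring of compound 2

The compounds below may be only part of what the source reports. "The series", "measured", "known", "first", "only" and "open" are said of these compounds alone.

Two compounds of the series have numbers in a functional assay on TK-10 cells (Homo sapiens) for inhibition, read by sulforhodamine B assay, with a stated time of 48 h; a lower number here means a stronger inhibitor of growth, a higher number a weaker inhibitor of growth. Compound 2 `COc1cc(C)cc(-c2nn(CC#N)cc2-c2ccnc(-c3ccc(N(C)C)cc3)c2)c1` gives 101 nM and stands lowest of the two. Compound 1 `Cc1cc(O)cc(-c2nn(CC#N)cc2-c2ccnc(-c3ccc(Oc4ccccc4)cc3)c2)c1` gives 4250 nM in this assay, a gap that lies beyond the scatter; compound 1 differs from compound 2 in more than one place, so the gap cannot be tied to a single change.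

Compound 3 `Cc1cc(O)cc(-c2nn(CC#N)cc2-c2ccnc(-c3ccc(N(C)C)cc3)c2)c1` has not been measured. It differs from compound 2 by hydrogen in place of methyl on an oxygen on an aromatic ring, methoxy to hydroxy. Going by the values given here, no measured pair isolates this change, so the direction is open. The step from compound 2 to compound 3 is expected to be small, a 1.8-fold higher number from compound 2 to compound 3 (0.25 log units; within the scatter), most likely within the scatter or a modest weakening. Compound 3 is expected to give 180 nM in this assay, with a range of 50 nM to 700 nM.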

Compound 3, concentration for 50% growth inhibition: 8400 nM
Beside the measured number, compound 3's estimate is 47-fold (1.67 log units) below it; the measured number lies above the stated range.
By their numbers in this assay, from the lowest: compound 2; then compounds 1 and 3 (each within the scatter of the next).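

Going by these compounds alone, on the 3-methoxy-5-methylphenyl group, methoxy to hydroxy is the first single change isolated in this assay, and it is a large one: an 83-fold higher number from compound 2 to compound 3 (1.92 log units; beyond the scatter). With hydroxy on the ring, dimethylamino in place of phenoxy on an aromatic carbon gives a 2.0-fold higher number from compound 1 to compound 3 (0.30 log units; within the scatter), so this pair does not separate the two groups. Nothing available gives a reason for the size of the methoxy to hydroxy step.

As far as these compounds go, whether the step follows from the methyl on the oxygen in particular stays open, as an ethoxy group, or an amine or a fluorine in place of the oxygen group, would test how narrow the requirement is. Also open, from the compounds shown here alone, is whether dimethylamino and phenoxy stay level when methoxy, rather than hydroxy, stands on the ring.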